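Aryl variation on the ring nitrogen of the thiazolidinone series

This account rests on a few compounds, and the source may have more. Where it says the series, first, only, none or still open, it means among the compounds named here.

Compound 1 `COc1ccc(F)cc1N1C(=O)CSC1c1cccc(C(=O)NCCCCc2ccccc2)c1` gives 32% in a functional assay on U2OS cells (Homo sapiens) for inhibition, read by CCK-8 assay, with a stated time of 72 h, tested at 1 uM (on this read-out higher numbers stand for more inhibition at the one concentration tested (going by the name of the read-out) and lower numbers for less inhibition), the highest of the three numbers available. Compound 2 `CC(F)(F)c1cccc(N2C(=O)CSC2c2cccc(C(=O)NCCCCc3ccccc3)c2)c1` gives 24% in this assay, a change of a number 8 percentage points lower from compound 1 to compound 2 (within the scatter). Compound 3 `COc1c(F)cccc1N1C(=O)CSC1c1cccc(C(=O)NCCCCc2ccccc2)c1` gives 12% in this assay, a change of a number 20 percentage points lower from compound 1 to compound 3 (beyond the scatter); between compound 2 and compound 3 the step is a number 12 percentage points lower from compound 2 to compound 3 (beyond the scatter).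

Compound 4 `COc1ccc(N2C(=O)CSC2c2cccc(C(=O)NCCCCc3ccccc3)c2)c(OC)c1` is not yet measured. It differs from compound 1 by 2,4-dimethoxyphenyl in place of 5-fluoro-2-methoxyphenyl on an amide-type nitrogen in a ring. Among the compounds with values here, no measured step exchanges the same two groups, so the three steps above bear on it only as a general picture: every change made so far on the amide-type nitrogen in the ring has left the number at or below that of compound 1, once within the scatter and twice beyond it. On that basis a modest decrease in this assay from compound 1 to compound 4 is expected, of roughly the size seen for compound 2, which cannot be separated from no change; the expected step is a number 10 percentage points lower from compound 1 to compound 4 (within the scatter). Compound 4 is therefore estimated at 22%, with a range from 5% to 38%.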

Compound 4, a percentage reported as inhibition, at one concentration (the size of the read-out at that concentration, not a potency): 37%
The estimate for compound 4 lay 15 percentage points below the measured number; the range from low to high includes it.
By their numbers in this assay, from the lowest: compound 3; then compounds 2, 1 and 4 (each within the scatter of the next, the first and the last beyond it).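

Notes on the aryl group on the amide-type nitrogen in the ring

In this assay, this position accepts 2,4-dimethoxyphenyl as well as 5-fluoro-2-methoxyphenyl, with a number 5 percentage points higher from compound 1 to compound 4 (within the scatter), so the two groups cannot be separated on this read-out and the earlier picture of every change leaving the number at or below that of compound 1 no longer offers a useful guide. The same group stands clearly apart from the other two aryl groups, with a number 25 percentage points higher from compound 3 to compound 4 (beyond the scatter) and a number 13 percentage points higher from compound 2 to compound 4 (beyond the scatter), and compound 3 is now beyond the scatter of all three other compounds. Compounds 1, 3 and 4 all carry a methoxy group at the same place on the aryl ring, yet they do not read alike, so that shared feature alone does not set the number among the listed compounds.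

Nothing measured here accounts for these differences.

From the compounds shown here alone, it remains open how an aryl ring carrying an amine or a carboxylic acid would read at this position, and whether a benzyl group or a pyridine ring could take the place of the aryl ring.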